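A few compounds are considered here, and "the series" means these few. Any claim that something is new, unique, unknown or untested is made for them only; others in the source may bear on it.

Values in a functional assay on MCF7 cells (Homo sapiens) for inhibition, read by CCK-8 assay, with a stated time of 48 h; a higher number here means a weaker inhibitor of growth, a lower number a stronger inhibitor of growth:
- compound 1 `CN1CCN(c2ccc(Nc3ncc(Cl)c(Nc4ccccc4)n3)nc2)CC1`: 51800 nM
- compound 2 `CN1CCN(c2ccc(Nc3ncc(Cl)c(NCc4ccccc4)n3)nc2)CC1`: 17300 nM
- compound 3 `Cc1cc(C)c(Nc2nc(Nc3ccc(N4CCN(C)CC4)cn3)ncc2Cl)c(C)c1`: 9470 nM
- compound 4 `COc1ccc(Nc2nc(Nc3ccc(N4CCN(C)CC4)cn3)ncc2Cl)cc1`: not yet measured

Compound 3 sits at the low end of the numbers in this assay, level with compound 2 within the scatter: a 1.8-fold lower number from compound 2 to compound 3 (0.26 log units; within the scatter). It stands clear of compound 1 only: a 5.5-fold lower number from compound 1 to compound 3 (0.74 log units; beyond the scatter). The next change is 4-methoxyphenyl in place of 2,4,6-trimethylphenyl on a nitrogen on an aromatic ring, with 4-methoxyphenyl in place of 2,4,6-trimethylphenyl on a nitrogen on an aromatic ring.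

Within the data shown here, no measured compound carries 4-methoxyphenyl, so no step isolates it. The closest guide is a 5.5-fold lower number from compound 1 to compound 3 (0.74 log units; beyond the scatter), read in reverse, since compound 4 gives up 2,4,6-trimethylphenyl as compound 1 does. The other step at this place, a 3.0-fold lower number from compound 1 to compound 2 (0.48 log units; beyond the scatter), is of similar modest size. Compound 4 is therefore expected to keep part of that gain and to land within the span set by compound 3 and compound 1. The expected change is a 2.1-fold higher number from compound 3 to compound 4 (0.32 log units; beyond the scatter), a modest rise in the number. For compound 4 the estimated value is 20000 nM, with an expected range of 7000 nM to 55000 nM.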

Compound 4, concentration for 50% growth inhibition: 8450 nM
Beside the measured number, compound 4's estimate is 2.4-fold (0.37 log units) above it, and the stated range covers the measured number.
By their numbers in this assay, from the lowest: compounds 4, 3 and 2 (each within the scatter of the next, the first and the last beyond it); then compound 1.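

In this assay, 4-methoxyphenyl and 2,4,6-trimethylphenyl cannot be told apart on the nitrogen on an aromatic ring (a 1.1-fold lower number from compound 3 to compound 4 (0.05 log units; within the scatter)), so the trimethyl pattern is not needed to stay at this level. A methoxy on the phenyl ring of compound 1 is enough for a step of similar size to the one seen with 2,4,6-trimethylphenyl (a 6.1-fold lower number from compound 1 to compound 4 (0.79 log units; beyond the scatter)). Compound 4 also stands just clear of the benzyl compound (a 2.0-fold lower number from compound 2 to compound 4 (0.31 log units; beyond the scatter)), a separation that compound 3 did not reach (a 1.8-fold lower number from compound 2 to compound 3 (0.26 log units; within the scatter)).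

Still open, from the compounds shown here alone, is whether methoxy itself matters or any group in that place would serve, which 4-hydroxyphenyl, 4-aminophenyl or 4-chlorophenyl would test. Nothing measured here explains why these steps take the sizes they do.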